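The source may report more compounds than this note shows. Statements on the series, on what has been measured and on what is new or still open speak of the compounds shown alone.

Among the compounds with values here, compound 1 `CCNC(=O)c1noc(-c2cc(C(C)C)c(O)cc2O)c1-c1cc(CN)no1` is one of three compounds measured in a functional assay on HCT-116 cells (Homo sapiens) for inhibition; on this read-out higher numbers stand for weaker inhibition and lower numbers for stronger inhibition. In this assay compound 1 gives 84 nM, the second highest of the three numbers. Compound 2 `CCNC(=O)c1noc(-c2cc(C(C)C)c(O)cc2O)c1-c1cc(CN(C)C)no1`, which carries dimethylamino in place of amino on a saturated chain carbon bound to an aromatic carbon, gives 92 nM; the step of a 1.1-fold higher number from compound 1 to compound 2 (0.04 log units; within the scatter), so these two are not distinguished. Compound 3 `CCNC(=O)c1noc(-c2cc(C(C)C)c(O)cc2O)c1-c1ccn(CC)n1` gives 25 nM, and the step of a 3.4-fold lower number from compound 1 to compound 3 (0.53 log units; beyond the scatter). The matching step a 3.7-fold lower number from compound 2 to compound 3 (0.57 log units; beyond the scatter).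

Compound 4 `CCNC(=O)c1noc(-c2cc(C(C)C)c(O)cc2O)c1-c1cnn(C(C)C)c1` is not yet measured. It differs from compound 1 in one place: 1-isopropyl-1H-pyrazol-4-yl in place of 3-(aminomethyl)-1,2-oxazol-5-yl on an aromatic carbon.

Within the data shown here, the steps that bear on this change are those into compound 3, where the same 3-(aminomethyl)-1,2-oxazol-5-yl group also left and a pyrazolyl group entered; both were modest and pointed toward a lower number. Among the measured compounds shown here, compound 4 carries a pyrazolyl group too, but with isopropyl instead of ethyl and joined through a different ring atom, and no measured step covers that difference directly. The expectation is therefore a modest step toward a lower number, a 2.4-fold lower number from compound 1 to compound 4 (0.38 log units; beyond the scatter), with wide uncertainty. Compound 4 is estimated to give 35 nM, in a range from 12 nM to 100 nM.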

Compound 4, half-maximal inhibitory concentration: 21 nM
Compound 4: middle estimate off by 1.7-fold (0.22 log units), on the high side, and the stated range covers the measured number.
By their numbers in this assay, from the lowest: compounds 4 and 3 (each within the scatter of the next); then compounds 1 and 2 (each within the scatter of the next).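

At this place on the shared core, on an aromatic carbon of the five-membered ring with one nitrogen and one oxygen, a second kind of pyrazolyl group also goes with stronger inhibition in this assay: the step is a 4.0-fold lower number from compound 1 to compound 4 (0.60 log units; beyond the scatter) against the aminomethyl group and a 4.4-fold lower number from compound 2 to compound 4 (0.64 log units; beyond the scatter) against the dimethylaminomethyl group. Compound 3 and compound 4 are not distinguished, with a 1.2-fold lower number from compound 3 to compound 4 (0.08 log units; within the scatter) when isopropyl replaces ethyl and the ring attachment changes in the same step, so this place accepts both pyrazolyl groups without a visible difference in the read-out. No measurement is at hand that would explain why either pyrazolyl group gives a lower number than the two aminomethyl-bearing groups.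

Going by these compounds, since the N-substituent and the ring attachment change together, the effect of each alone remains open, and they could even offset each other; a 1-ethyl-1H-pyrazol-4-yl group would separate the two. A pyrazole carrying an aminomethyl group would also show whether the amine or the ring accounts for the gap between these pairs.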